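Replacing the Open Chain of Compound 2 with Two Rings

The compounds below may be only part of what the source reports. "The series", "measured", "known", "first", "only" and "open" are said of these compounds alone.

Compound 1 `CCc1cccc(CC)c1N1CCn2cc(-c3nc(Nc4ccc(N5CCC(C(=O)N6CCN(C)CC6)CC5)cc4OC)nc4[nH]ccc34)cc2C1=O` and compound 2 `CCc1cccc(CC)c1N1CCn2cc(-c3nc(Nc4ccc(N5CCC(C(=O)N(C)CCN(C)C)CC5)cc4OC)nc4[nH]ccc34)cc2C1=O` share one core and differ only in the group on a carbonyl carbon. In a functional assay on CAL-51 cells (Homo sapiens) for inhibition, read by luminescence, with a stated time of 3 days (on this read-out lower numbers stand for stronger inhibition and higher numbers for weaker inhibition), compound 1 gives 5 nM and compound 2 gives 7 nM. Going by the values given here, these are the only two numbers available, and compound 2 sits level with compound 1, the step being a 1.4-fold higher number from compound 1 to compound 2 (0.15 log units; within the scatter). That step exchanged 4-methylpiperazin-1-yl for (2-(dimethylamino)ethyl)(methyl)amino.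

Compound 3 `CCc1cccc(CC)c1N1CCn2cc(-c3nc(Nc4ccc(N5CCC(C(=O)N6CC7(CN(C)C7)C6)CC5)cc4OC)nc4[nH]ccc34)cc2C1=O` keeps the core and changes the same place, on a carbonyl carbon whose other neighbour is a saturated ring carbon: a group of 8 heavy atoms (6 carbon, 2 nitrogen; 2 four-membered non-aromatic rings with 1 hetero atom each) in place of a group of 7 heavy atoms (5 carbon, 2 nitrogen; no ring), on a carbonyl carbon. Among the compounds with values here, no measured compound carries four-membered rings, so the evidence is thin. Within the data shown here, only one measured step bears on this change, the exchange at that carbonyl carbon of a ring-bearing group for an open chain, which gave a 1.4-fold higher number from compound 1 to compound 2 (0.15 log units; within the scatter). On that basis, no shift beyond the scatter is expected in this assay, and the expected step is no change at the digits printed from compound 2 to compound 3 (within the scatter). Compound 3 is therefore estimated at 7 nM, with an expected range from 3 nM to 18 nM.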

Compound 3, half-maximal inhibitory concentration in the CAL-51 assay: 16 nM
Compound 3: the middle estimate sits 2.3-fold (0.36 log units) below what was measured; measured number inside the range.
By their numbers in the CAL-51 assay, from the lowest: compounds 1 and 2 (each within the scatter of the next); then compound 3.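

At this carbonyl carbon, the CAL-51 assay now separates the groups, with compound 3 at 16 nM. The 4-methylpiperazin-1-yl ring and the open chain had stayed within the scatter of each other, whereas the group with 2 four-membered non-aromatic rings gives a 2.3-fold higher number from compound 2 to compound 3 (0.36 log units; beyond the scatter) and a 3.2-fold higher number from compound 1 to compound 3 (0.51 log units; beyond the scatter), which makes compound 3 the weakest of the three and shows that this position is not indifferent to the group it carries. In a physicochemical assay for solubility, read by HPLC, in phosphate buffer, measured as kinetic solubility, with a stated time of 24 h, at pH 7.4, tested at 200 uM (on this read-out higher numbers stand for higher solubility and lower numbers for lower solubility), compound 2 gives 125000 nM and compound 3 gives 180000 nM, and the same exchange gives a 1.4-fold higher number from compound 2 to compound 3 (0.16 log units; within the scatter), so it moves the number beyond the scatter in the CAL-51 assay but not in the physicochemical assay. Nothing measured here accounts for the step in inhibition.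

The compounds shown leave open whether a dimethylamino group on a single four-membered ring would stay level with compound 1 and compound 2 or fall with compound 3. Also open, as far as these compounds go, is how a morpholine, which carries an oxygen in place of the second amine nitrogen, would read at this carbonyl carbon in the CAL-51 assay.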